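Notes on a small set: aryl change on the ring carbon

The source may report more compounds than this note shows. Statements on the series, on what has been measured and on what is new or still open speak of the compounds shown alone.

compound 1 `O=C(NO)c1ccc(NCc2nc(-c3ccccc3)nn2-c2cccc(Cl)c2)cc1` — 62.3%
compound 2 `Cc1ccccc1-c1nc(CNc2ccc(C(=O)NO)cc2)n(-c2ccccc2)n1` — 53.2%
compound 3 `Cc1cc(C)cc(-n2nc(-c3ccccc3)nc2CNc2ccc(C(=O)NO)cc2)c1` — 49.8%

In an assay on Sf9 cells for inhibition of protein deacetylase HDAC6 (Homo sapiens), read by fluorescence, with a stated time of 40 min, tested at 100 nM (a higher number here means more inhibition at the concentration tested (going by the name of the read-out), a lower number less inhibition), compound 1 gives 62.3%, compound 2 gives 53.2% and compound 3 gives 49.8%. Compound 2 stands second highest of the three numbers; compound 3 and compound 1 both lie within the scatter of it. Among the compounds with values here, the one step measured, a number 12.5 percentage points lower from compound 1 to compound 3 (beyond the scatter), concerns the group on the aromatic nitrogen, not the ring carbon. Compound 4 `O=C(NO)c1ccc(NCc2nc(-c3cccc4cnccc34)nn2-c2ccccc2)cc1` carries isoquinolin-5-yl in place of 2-methylphenyl on an aromatic carbon. Within the data shown here, no measured step touches that position, so the step from compound 1 to compound 3 bears on it only indirectly. Compound 4 is expected to show a number 3.2 percentage points lower from compound 2 to compound 4 (within the scatter), nothing beyond the scatter. Compound 4 is estimated at 50%, range 35% to 65%.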

Compound 4, a percentage reported as inhibition, at one concentration (the size of the read-out at that concentration, not a potency): 40.2%
Beside the measured number, compound 4's estimate is 9.8 percentage points above it, within the range that was stated.
By their numbers in this assay, from the lowest: compounds 4, 3, 2 and 1 (each within the scatter of the next, the first and the last beyond it).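

In this assay, isoquinolin-5-yl in place of 2-methylphenyl gives a number 13 percentage points lower from compound 2 to compound 4 (beyond the scatter) as the first step read at this aromatic carbon, so the group held there does move the read-out. The entering group brings 10 heavy atoms against 7 and 1 hydrogen-bond acceptor against 0, and this single step cannot separate those differences. No measurement at hand accounts for the step.

Open, as far as these compounds go, is how a pyridin-3-yl ring or an aminomethyl group would read at this aromatic carbon. Also open, from the compounds shown here alone, is whether isoquinolin-5-yl gives a similar step alongside 3-chlorophenyl on the aromatic nitrogen.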